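Moving the hydroxyl of compound 2 from one position to another

The compounds below may be only part of what the source reports. "The series", "measured", "known", "first", "only" and "open" are said of these compounds alone.

compound 1 `Oc1cccc(-c2cc(-c3ccccc3F)cc(-c3ccccc3O)n2)c1`: 31100 nM
compound 2 `Oc1ccc(-c2cc(-c3ccccc3F)cc(-c3ccccc3O)n2)cc1`: > 50000 nM
compound 3 `Oc1ccc(-c2cc(-c3ccc(F)cc3)cc(-c3ccccc3O)n2)cc1`: > 50000 nM

In a functional assay on HeLa cells (Homo sapiens) for inhibition (a higher number here means a weaker inhibitor, a lower number a stronger inhibitor), compound 1 gives 31100 nM. Compound 2 reaches only a limit of the assay, > 50000 nM. Compound 3 likewise stops at a limit, > 50000 nM. Compound 2 therefore stands at the limit of > 50000 nM in this assay, at which 2 of the 3 values shown sit, with no number of its own. Compound 4 `Oc1ccc(-c2cc(-c3ccccc3F)cc(-c3ccc(O)cc3)n2)cc1` differs from compound 2 by 4-hydroxyphenyl in place of 2-hydroxyphenyl on an aromatic carbon. Of the measured steps, a step that the two limits leave unreadable from compound 2 to compound 3 gives no readable size. Compound 4 is expected to stay at the limit because an at least 1.6-fold higher number from compound 1 to compound 2 (0.20 log units; that floor lies within the scatter) brought no gain when a hydroxyphenyl was likewise rearranged. The step that the limit leaves unreadable from compound 2 to compound 4 is thus estimated as none beyond the scatter. Compound 4 is estimated at 60000 nM, within 20000 nM to 200000 nM.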

Compound 4, half-maximal inhibitory concentration: > 50000 nM
Compound 4 gave a limit, no number (the forecaster's own chance of this, stated with the estimate: 70%); the middle value does not contradict the limit.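

Compound 2 and compound 4 both stop at a limit with no number of their own, so the step between them cannot be read. The compounds shown leave open how strongly compound 2, compound 3 and compound 4 actually inhibit.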